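The source may report more compounds than this note shows. Statements on the series, on what has been measured and on what is new or still open speak of the compounds shown alone.

In a functional assay on MDA-MB-231 cells (Homo sapiens) for antiproliferative activity, read by MTT assay, with a stated time of 72 h (a higher number here means a weaker inhibitor, a lower number a stronger inhibitor), compound 1 `CC1=CC[C@H]2[C@H](CC[C@]2(C)O)C(C)(C)[C@@H]1CC[C@H]1[C@]2(C)CC[C@H](OC(=O)c3ccccc3)C(C)(C)O[C@H]2CC[C@@]1(C)O` gives 16100 nM. Compound 2 `CC1=CC[C@H]2[C@H](CC[C@]2(C)O)C(C)(C)[C@@H]1CC[C@H]1[C@]2(C)CC[C@H](OC(=O)c3ccc(Cl)cc3)C(C)(C)O[C@H]2CC[C@@]1(C)O` gives 10300 nM, which lies within the usual scatter of compound 1, so the two numbers cannot be ranked. These two compounds share the same core and differ at one place, with chloro in place of hydrogen on an aromatic carbon. Within the data shown here, that swap is the only measured step here: a 1.6-fold lower number from compound 1 to compound 2 (0.19 log units; within the scatter).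

Compound 3 `CC1=CC[C@H]2[C@H](CC[C@]2(C)O)C(C)(C)[C@@H]1CC[C@H]1[C@]2(C)CC[C@H](OC(=O)c3ccc(F)cc3)C(C)(C)O[C@H]2CC[C@@]1(C)O` has not yet been measured. Its difference from compound 2 is fluoro in place of chloro on an aromatic carbon. In words, this is fluoro in place of chloro on an aromatic carbon, on the same six-membered aromatic ring of carbon only, para to a large group. Among the measured compounds shown here, no measured step covers this exact swap, so the closest guide is the small step to compound 2, a 1.6-fold lower number from compound 1 to compound 2 (0.19 log units; within the scatter). On that evidence, no step beyond the scatter is expected, and the direction cannot be called with any confidence. The estimated step is a 1.2-fold higher number from compound 2 to compound 3 (0.07 log units; within the scatter). The expected value for compound 3 is 12000 nM, with an estimated range of 6500 nM to 22000 nM.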

Compound 3, half-maximal inhibitory concentration: 11300 nM
For compound 3 the middle estimate is 1.1-fold (0.03 log units) above the measured one; measured number inside the range.
By their numbers in this assay, from the lowest: compounds 2, 3 and 1 (each within the scatter of the next).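

In this assay, replacing chloro with fluoro on this aromatic carbon, para to a large group, gives only a small shift (a 1.1-fold higher number from compound 2 to compound 3 (0.04 log units; within the scatter)). Fluoro in place of hydrogen at the same carbon also stays small (a 1.4-fold lower number from compound 1 to compound 3 (0.15 log units; within the scatter)), so this carbon has now carried hydrogen, chloro and fluoro, and none of the three compounds can be ranked against another. The earlier pair showed this for one halogen only, while the new result extends it to a second, so the absence of a readable difference among these compounds does not rest on chloro alone, and no measured property is available here to account for the result.

The compounds shown all carry a small single atom at this carbon, so it remains open whether a larger or very different group there, such as an amine, a methoxy group or a carboxylic acid, would move the number beyond the scatter. Also open, from the compounds shown here alone, is whether the same swaps would matter on other carbons of the aromatic ring, or with the 4-fluorophenyl group joined to the shared core through something other than the carbonyl-oxygen link.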